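Moving the chloro group: compound 3 to compound 4

A few compounds are considered here, and "the series" means these few. Any claim that something is new, unique, unknown or untested is made for them only; others in the source may bear on it.

Measured so far in a physicochemical assay for lipophilicity (on this read-out lower numbers stand for lower lipophilicity and higher numbers for higher lipophilicity), for this series:
compound 1 `C[C@H]1CC[C@@H]2[C@@H](OC(=O)[C@]23CC(c2ccccc2)N(c2ccccc2)O3)[C@]2(C)C(=O)C=C[C@@]12O` gives 3.19
compound 2 `C[C@H]1CC[C@@H]2[C@@H](OC(=O)[C@]23CC(c2c(F)cccc2F)N(c2ccccc2)O3)[C@]2(C)C(=O)C=C[C@@]12O` gives 3.42
compound 3 `C[C@H]1CC[C@@H]2[C@@H](OC(=O)[C@]23CC(c2cccc(Cl)c2)N(c2ccccc2)O3)[C@]2(C)C(=O)C=C[C@@]12O` gives 3.87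

In this assay compound 3 stands highest of the three, with its gaps to both others beyond the scatter. The next structure, compound 4 `C[C@H]1CC[C@@H]2[C@@H](OC(=O)[C@]23CC(c2ccccc2Cl)N(c2ccccc2)O3)[C@]2(C)C(=O)C=C[C@@]12O`, differs from it as follows: 2-chlorophenyl in place of 3-chlorophenyl on a saturated ring carbon with 2-chlorophenyl in place of 3-chlorophenyl on a saturated ring carbon next to the ring nitrogen. Among the compounds with values here, no measured step moves a chloro group in this way, so the evidence is indirect. Chloro in place of hydrogen gave a number 0.68 log units higher from compound 1 to compound 3 (beyond the scatter) and the 2,6-difluorophenyl exchange gave a number 0.45 log units higher from compound 2 to compound 3 (beyond the scatter) while the difluoro step itself gave a number 0.23 log units higher from compound 1 to compound 2 (within the scatter) in this series. Compound 4 keeps the same atoms as compound 3, so most of the rise seen in a number 0.68 log units higher from compound 1 to compound 3 (beyond the scatter) is expected to remain. The expected change is a number 0.12 log units lower from compound 3 to compound 4 (within the scatter) and no clear shift is expected. For compound 4 the estimate is 3.75 with an expected range from 3.4 to 4.1 in this assay.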

Compound 4, partition coefficient: 3.87
Estimate against measurement, compound 4: 0.12 log units below; the range from low to high includes it.
By their numbers in this assay, from the lowest: compounds 1 and 2 (each within the scatter of the next); then compounds 3 and 4 (each within the scatter of the next).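

In this assay the exchange of 3-chlorophenyl for 2-chlorophenyl on the saturated ring carbon gives no change at the digits printed from compound 3 to compound 4 (within the scatter) and so does not separate these two chlorophenyl groups. Within the data shown here, the gains previously seen only with 3-chlorophenyl also appear with 2-chlorophenyl, with a number 0.68 log units higher from compound 1 to compound 4 (beyond the scatter) and a number 0.45 log units higher from compound 2 to compound 4 (beyond the scatter). No available measurement accounts for this outcome.

On these data alone, it remains open whether the chloro placement would matter as little for another substituent on this aromatic ring, such as an amine or a carboxylic acid. The compounds shown also leave open how a longer chain on this saturated ring carbon would compare with the aromatic groups.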